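From methylamino to dimethylamino at the assay limit

The source may report more compounds than this note shows. Statements on the series, on what has been measured and on what is new or still open speak of the compounds shown alone.

Compound 1 `CNc1ncnc2c1c(-c1ccsc1)cn2[C@@H]1O[C@H](CO)[C@@H](O)[C@H]1O` gives > 100000 nM as a limit
Compound 2 `CNc1ncnc2c1c(-c1ccccc1)cn2[C@@H]1O[C@H](CO)[C@@H](O)[C@H]1O` gives > 100000 nM as a limit
Compound 3 `C#Cc1cn([C@@H]2O[C@H](CO)[C@@H](O)[C@H]2O)c2ncnc(NC)c12` gives > 100000 nM as a limit

In an ADME assay on MRC5 cells (Homo sapiens), read by MTT assay, with a stated time of 72 h (on this read-out higher numbers stand for weaker inhibition and lower numbers for stronger inhibition), compound 3 stands at the limit > 100000 nM and has no number. The whole set offers only the limit of > 100000 nM in this assay, at which 3 of the 3 values shown sit, as its evidence. Compound 4 `C#Cc1cn([C@@H]2O[C@H](CO)[C@@H](O)[C@H]2O)c2ncnc(N(C)C)c12` differs from compound 3 by methyl in place of hydrogen on a nitrogen on an aromatic ring as its change, methyl in place of hydrogen on a nitrogen on an aromatic ring. The measured steps all concern a group on an aromatic carbon, not this nitrogen, and none has a size: a step that the two limits leave unreadable from compound 1 to compound 2 and a step that the two limits leave unreadable from compound 1 to compound 3 and a step that the two limits leave unreadable from compound 2 to compound 3 are the three. No step beyond the scatter is therefore expected in this assay in either direction. For compound 4 the expected value is 100000 nM with an estimated range from 30000 nM to 300000 nM and a report of only a limit is likely.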

Compound 4, half-maximal inhibitory concentration: 36100 nM
Compound 4: middle estimate off by 2.8-fold (0.44 log units), on the high side; measured number inside the range.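

In this assay, methyl in place of hydrogen on a nitrogen on an aromatic ring gives an at least 2.7-fold lower number from compound 3 to compound 4 (0.44 log units; beyond the scatter). This nitrogen is therefore a place where the read-out comes off the limit, whereas the earlier changes, all on an aromatic carbon, gave steps that cannot be read. Compound 4 alone carries a number: the limit of > 100000 nM in this assay, at which 3 of the 4 values shown sit.

Going by these compounds, it remains open whether the same methyl change would act alike with phenyl or thiophen-3-yl in place of ethynyl. Also open, on these data alone, is what an ethyl chain or a pyrrolidine ring would do on this nitrogen.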